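The compounds below may be only part of what the source reports. "The series", "measured", "known", "first", "only" and "open" are said of these compounds alone.

In a functional assay on Jurkat cells (Homo sapiens) for inhibition, read by CCK-8 assay, with a stated time of 48 h (a lower number here means a stronger inhibitor of growth, a higher number a weaker inhibitor of growth), compound 1 `Cc1ccccc1Nc1nc(Nc2ccccc2)ncc1Cl` gives > 100000 nM, which is a limit of the assay and not a number. Compound 2 `Cc1ccccc1Nc1nc(NCc2ccncc2)ncc1Cl` gives > 100000 nM, again a limit. Compound 3 `CN1CCN(c2ccc(Nc3ncc(Cl)c(Nc4ccccc4)n3)nc2)CC1` gives > 100000 nM, also only a limit. Compound 3 therefore has no exact value, and it stands with the other two compounds at one shared ceiling: the limit of > 100000 nM in this assay, at which 3 of the 3 values shown sit.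

The next compound, compound 4 `CN1CCN(c2ccc(Nc3ncc(Cl)c(NCc4ccc(F)cc4)n3)nc2)CC1`, differs from compound 3 in one group: 4-fluorobenzyl in place of phenyl on a nitrogen on an aromatic ring. In words, 4-fluorobenzyl takes the place of phenyl on a nitrogen on an aromatic ring. The closest measured change also falls on a nitrogen on an aromatic ring, though not the same one: a step that the two limits leave unreadable from compound 1 to compound 2. That step offers no size to carry over, so the expectation here rests on very little. Any number for compound 4 would mean stronger growth inhibition than the limit of compound 3 shows, yet another limit is about as likely as a number. The expected change in this assay, pointing towards stronger inhibition, is an at least 2.5-fold lower number from compound 3 to compound 4 (0.39 log units; beyond the scatter). For compound 4 the estimated growth-inhibition concentration is 40000 nM, with an expected range from 5000 nM to 100000 nM.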

Compound 4, concentration for 50% growth inhibition: > 100000 nM
Compound 4 ended at the assay's limit (the forecaster's own chance of this, stated with the estimate: 50%); middle value at least 2.5-fold (0.39 log units) away from the limit.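

No new step can be read: compound 3 and compound 4 both give only a limit and not a number, so the effect of 4-fluorobenzyl in place of phenyl stays unreadable, and the series has one shared ceiling: the limit of > 100000 nM in this assay, at which 4 of the 4 values shown sit.

The compounds shown leave open which change to the shared core, if any, would give a measured number instead of a limit.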